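Benzyl in Place of Cyclopentyl on the Amide Nitrogen

The source may hold more compounds than are shown below. What is called first, only, known or untested is meant among the compounds shown, and "the series" means these compounds.

Among the compounds with values here, compound 2 `C/C(=C\c1ccc(C(=O)Oc2ccc(C(=N)N)cc2)cc1)C(=O)N(CC(=O)O)C1CCCC1` holds the only number in an in vitro ADME assay on a cell-free system (plasma) for pharmacokinetics; a higher number here means that the compound lasts longer, a lower number that the compound disappears faster: compound 2 gives 0.383 h. Compound 1 `CCOC(=O)CN(Cc1ccccc1)C(=O)/C(C)=C/c1ccc(C(=O)Oc2ccc(C(=N)N)cc2)cc1` gives < 0.0167 h in this assay, which is a limit of the assay and not a number (the limit of < 0.0167 h in this assay, at which 1 of the 2 values shown sits). Compound 3 `C/C(=C\c1ccc(C(=O)Oc2ccc(C(=N)N)cc2)cc1)C(=O)N(CC(=O)O)Cc1ccccc1` has not yet been measured; it differs from compound 2 by benzyl in place of cyclopentyl on an amide-type nitrogen. Within the data shown here, no measured pair shows what this change does in this assay, so the step is expected to stay within the scatter. Compound 3 is therefore estimated at 0.35 h, between 0.12 h and 1 h. The expected step is a 1.1-fold lower number from compound 2 to compound 3 (0.04 log units; within the scatter).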

Compound 3, half-life: > 1 h
Compound 3: only a limit was reported (the forecaster's own chance of this, stated with the estimate: 15%); middle value at least 2.8-fold (0.45 log units) from the limit.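

Benzyl in place of cyclopentyl on the amide-type nitrogen proves to be a real change in this assay, giving an at least 2.6-fold higher number from compound 2 to compound 3 (0.41 log units; beyond the scatter). With benzyl on that nitrogen, hydrogen in place of ethyl on an oxygen next to a carbonyl group gives an at least 59-fold higher number from compound 1 to compound 3 (1.77 log units; beyond the scatter). Compound 3 stands at a limit of the assay and not at a number: the limit of > 1 h in this assay, at which 1 of the 3 values shown sits.

Going by these compounds, the true size of both steps stays open, and so does how far the half-life could rise. On these data alone, whether phenethyl or a longer chain on that nitrogen would match benzyl also remains unknown.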